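This account rests on a few compounds, and the source may have more. Where it says the series, first, only, none or still open, it means among the compounds named here.

Of the compounds shown here, three built on one shared core have been tested in a functional assay on U-87MG ATCC cells for antiproliferative activity against U-87 MG (Homo sapiens), read by MTT assay, with a stated time of 48 h, tested at 50 uM; a higher number here means a weaker effect of the compound at the concentration tested, a lower number a stronger effect. Compound 1 `COc1ccc(-c2nc(SCC(=O)c3sc(-c4ccccc4)nc3C)[nH]c(=O)c2C#N)cc1` gives 52.1%. Compound 2 `COc1ccc(-c2nc(C)c(C(=O)CSc3nc(-c4ccc(OC)cc4)c(C#N)c(=O)[nH]3)s2)cc1` gives 32.6%, and compound 3 `COc1ccc(-c2nc(C)c(C(=O)CSc3nc(-c4cccc(OC)c4)c(C#N)c(=O)[nH]3)s2)cc1` gives 43.2%. Among these three numbers compound 3 stands second highest; its gap to compound 1 lies within the usual scatter, while its gap to compound 2 lies beyond it. Compound 4 `COc1cccc(-c2nc(SCC(=O)c3sc(-c4ccccc4)nc3C)[nH]c(=O)c2C#N)c1` differs from compound 3 in a single place: hydrogen in place of methoxy on an aromatic carbon. The measured step that bears most directly on this change runs in the opposite direction, from hydrogen to methoxy, and gave a number 19.5 percentage points lower from compound 1 to compound 2 (beyond the scatter). The other measured step, a number 10.6 percentage points higher from compound 2 to compound 3 (beyond the scatter), concerns a different part of the molecule and was smaller. Reversing the first of these steps from the starting point of compound 3 suggests an increase of roughly the same size, so the expected step is a number 17.8 percentage points higher from compound 3 to compound 4 (beyond the scatter). Compound 4 is accordingly estimated to give 61% in this assay, within a range from 46% to 76%.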

Compound 4, a percentage reported as activity, at one concentration (the size of the read-out at that concentration, not a potency): 80.3%
Estimate against measurement, compound 4: 19.3 percentage points below; measured number above the stated range.
By their numbers in this assay, from the lowest: compound 2; then compounds 3 and 1 (each within the scatter of the next); then compound 4.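

In this assay, hydrogen in place of methoxy on this ring again weakens the effect, now with the other aryl group as 3-methoxyphenyl, giving a number 37.1 percentage points higher from compound 3 to compound 4 (beyond the scatter). The direction therefore holds on both cores, but the size of the step depends on the group elsewhere in the molecule: the same change on two cores in this assay, a number 19.5 percentage points lower (beyond the scatter) from compound 1 to compound 2 and a number 37.1 percentage points lower (beyond the scatter) from compound 4 to compound 3, 17.6 percentage points apart, beyond the scatter of two such steps

Moving the methoxy on the other aryl group from the 4-methoxyphenyl to the 3-methoxyphenyl arrangement also keeps its direction, giving a number 28.2 percentage points higher from compound 1 to compound 4 (beyond the scatter), and its size likewise depends on the core: the same change on two cores in this assay, a number 10.6 percentage points higher (beyond the scatter) from compound 2 to compound 3 and a number 28.2 percentage points higher (beyond the scatter) from compound 1 to compound 4, 17.6 percentage points apart, beyond the scatter of two such steps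

The two changes therefore do not act as fixed, separate increments across these four compounds. On these data alone, only hydrogen and methoxy have been seen at this position, so the outcome with a hydroxyl, an amine or a longer ethoxy chain remains open. A read-out at one concentration also gives no potency for any of these compounds.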